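The compounds below may be only part of what the source reports. "The series", "measured", "known", "first", "only" and "open" are said of these compounds alone.

Within the data shown here, the three compounds measured so far share one core and are compared in a functional assay on MM1 cells (Homo sapiens) for antiproliferative activity, read by MTT assay, with a stated time of 72 h; a lower number here means a stronger inhibitor, a higher number a weaker inhibitor. Compound 1 `N#C/C(=C\c1cccc(Br)n1)C(=O)NC(c1ccccc1)C1CC1` gives 1100 nM in this assay. Compound 2 `CCC[C@H](NC(=O)/C(C#N)=C/c1cccc([N+](=O)[O-])c1)c1ccccc1` gives 1730 nM in this assay. Compound 3 `N#C/C(=C\c1ccc(-c2cccc([N+](=O)[O-])c2)o1)C(=O)NC(c1ccccc1)C1CC1` stands apart from these two: for compound 3 this assay reports only a limit, > 10000 nM, and not a number. That limit is the limit of > 10000 nM in this assay, at which 1 of the 3 values shown sits. So on the numbers shown, compound 3 is the weakest of the three, and how far it lies past the limit is unknown.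

Compound 4 `CCC(NC(=O)/C(C#N)=C/c1ccc(-c2cccc([N+](=O)[O-])c2)o1)c1ccccc1` differs from compound 3 in one place: ethyl in place of cyclopropyl on a saturated chain carbon bound to an amide-type nitrogen and an aromatic carbon. This is a small change at the end of the molecule away from the side that sets compound 3 apart from compound 1 and compound 2. In this assay no step beyond the scatter is expected from compound 3 to compound 4, which is a step that the limit leaves unreadable from compound 3 to compound 4. Compound 4 is therefore expected to give about 15000 nM, within the range from 5000 nM to 40000 nM, most likely again only as a limit.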

Compound 4, half-maximal inhibitory concentration: > 10000 nM
Compound 4 ended at the assay's limit (the forecaster's own chance of this, stated with the estimate: 70%); the middle value does not contradict the limit.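

Among these compounds, compound 3 and compound 4 both end at a limit and not at a number, so no step from cyclopropyl to ethyl can be read between them: the limit of > 10000 nM in this assay, at which 2 of the 4 values shown sit. The compounds shown leave open how far past that limit each one lies.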